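This account rests on a few compounds, and the source may have more. Where it says the series, first, only, none or still open, it means among the compounds named here.

Compound 1, `CN(Cc1ccccc1)C(=O)c1cc2c(Cc3ccccc3)n[nH]c2cc1O`, gives 980 nM in a functional assay on A2780 cells (Homo sapiens) for antiproliferative activity, read by resazurin assay, with a stated time of 72 h; a lower number here means a stronger inhibitor, a higher number a weaker inhibitor.
Compound 2, `CN(Cc1ccccc1Br)C(=O)c1cc2c(Cc3ccccc3)n[nH]c2cc1O`, gives 1200 nM in this assay.
Compound 3, `CN(Cc1ccccc1)C(=O)c1cc2c(Cc3cccc(Cl)c3)n[nH]c2cc1O`, gives 410 nM in this assay.

Compound 1 and compound 2 differ in one place: bromo in place of hydrogen on an aromatic carbon. This change carried a 1.2-fold higher number from compound 1 to compound 2 (0.09 log units; within the scatter), so the two values stand within the scatter of each other and no direction can be read from them. Compound 1 and compound 3 differ in another place: chloro in place of hydrogen on an aromatic carbon. Here the step was a 2.4-fold lower number from compound 1 to compound 3 (0.38 log units; beyond the scatter), and compound 3 holds the lowest number of the three, with compound 1 and compound 2 both beyond the scatter above it.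

Compound 4, `CN(Cc1ccccc1Br)C(=O)c1cc2c(Cc3cccc(Cl)c3)n[nH]c2cc1O`, has not yet been measured in this assay. It differs from compound 3 in one place: bromo in place of hydrogen on an aromatic carbon. The place of this change is described in the same words as for the pair of compound 1 and compound 2, so it is the same change made on the core of compound 3 rather than on the core of compound 1. Going by the values given here, the only guide to its effect is the single measured instance, and that instance stayed within the scatter.

Among the compounds with values here, the expected step is therefore a 1.2-fold higher number from compound 3 to compound 4 (0.09 log units; within the scatter), set beside a 1.2-fold higher number from compound 1 to compound 2 (0.09 log units; within the scatter), resting on the one earlier occurrence in compound 1 and compound 2. Compound 4 is accordingly estimated at 500 nM, with the range 250 nM to 1000 nM allowing for the usual spread and for the possibility that the change behaves differently on the core of compound 3.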

Compound 4, half-maximal inhibitory concentration: 130 nM
Estimate against measurement, compound 4: 3.8-fold (0.59 log units) above; measured number below the stated range.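

In this assay, the change from benzyl to 2-bromobenzyl gave a 3.2-fold lower number from compound 3 to compound 4 (0.50 log units; beyond the scatter), so the result of the earlier pair did not carry over from one core to the other: the same change on two cores in this assay, a 1.2-fold higher number (0.09 log units; within the scatter) from compound 1 to compound 2 and a 3.2-fold lower number (0.50 log units; beyond the scatter) from compound 3 to compound 4, 3.9-fold (0.59 log units) apart, beyond the scatter of two such steps. Seen from the other side, the chloro change gave a 9.2-fold lower number from compound 2 to compound 4 (0.97 log units; beyond the scatter), which is a larger step than the same change made without the bromo: the same change on two cores in this assay, a 2.4-fold lower number (0.38 log units; beyond the scatter) from compound 1 to compound 3 and a 9.2-fold lower number (0.97 log units; beyond the scatter) from compound 2 to compound 4, 3.9-fold (0.59 log units) apart, beyond the scatter of two such steps. Within these four compounds, the two changes therefore do not add up independently, and a step measured on one core is a poor guide to the same step on the other, but this rests on a single set of four compounds and shows neither the reason for the gap nor whether it would recur on any further core.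

The compounds shown leave open whether a fluoro or methyl group in place of the bromo, or a methoxy group in place of the chloro, would show the same dependence on the rest of the molecule. They also leave open how a longer chain in place of the methyl on the amide nitrogen, or an amine or a carboxylic acid on either benzyl group, would behave on these cores.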